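The source may hold more compounds than are shown below. What is called first, only, known or untested is meant among the compounds shown, and "the series" means these compounds.

Compound 1 `O=C1c2ccc(OCc3cccc(-c4ccc(Cl)cc4F)c3)cc2CN1C1CCCC1` is the reference point of this account. In an assay on HEK293 cells for positive allosteric modulation of metabotropic glutamate receptor 2 (Rattus norvegicus), read by thallium flux (a lower number here means that less compound is needed, a higher number that more compound is needed for the effect), compound 1 gives > 5000 nM, which is a limit of the assay rather than a number, as recorded at the limit of > 5000 nM in this assay, at which 1 of the 2 values shown sits. A second compound built on a different core, compound 2 `Cn1sc2cc(OCc3cccc(-c4ccc(Cl)c(C(=O)O)c4)c3)ccc2c1=O`, gives 640 nM in this assay; it likewise carries a carboxy group on its outer ring. Compound 3 `COc1ccc(-c2cccc(COc3ccc4c(c3)CN(C3CCCC3)C4=O)c2)cc1C(=O)O` keeps the core of compound 1 and alters only the outer ring: 3-carboxy-4-methoxyphenyl in place of 4-chloro-2-fluorophenyl on an aromatic carbon. For the measured compounds named here, no measured pair shows a step of exactly this kind, so its size can only be judged from what compound 2 shows. Compound 3 is expected to move into the measurable range, and the step of an at least 3.3-fold lower number from compound 1 to compound 3 (0.52 log units; beyond the scatter) is expected to run toward less compound being needed. Compound 3 is estimated at 1500 nM, with a range from 400 nM to 6000 nM.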

Compound 3, half-maximal effective concentration: 170 nM
Beside the measured number, compound 3's estimate is 8.8-fold (0.95 log units) above it, and the stated range ends above it.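

In this assay, the outer ring at this position decides whether the core of compound 1 gives a measurable value at all: 3-carboxy-4-methoxyphenyl in place of 4-chloro-2-fluorophenyl on an aromatic carbon brings an at least 29-fold lower number from compound 1 to compound 3 (1.46 log units; beyond the scatter). From the compounds shown here alone, the value of compound 1 is a limit of the assay, so the true size of this step stays open and only its lower bound is known: the limit of > 5000 nM in this assay, at which 1 of the 3 values shown sits. Compound 3 now gives this core a measured number, which compound 1 could not provide.

The carboxy and methoxy groups enter together while the chlorine and fluorine leave together, so the compounds shown do not assign the step to any one of these groups. Going by these compounds, it also remains open whether a tetrazole or a primary amide could stand in place of the carboxylic acid on this ring.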